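Amide aryl swap in a series without measurable cytotoxicity

A few compounds are considered here, and "the series" means these few. Any claim that something is new, unique, unknown or untested is made for them only; others in the source may bear on it.

Measured so far in a toxicity assay on THP-1 cells (Homo sapiens) for inhibition; a lower number here means that less compound is tolerated, a higher number that more compound is tolerated:
Compound 1, `COc1ccc(-c2noc(NC(=O)c3ccc(F)cc3)c2C)cc1`, gives > 100000 nM, which is a limit of the assay and not a number.
Compound 2, `COc1ccc2c(c1)nc(NC(=O)c1ccc(F)cc1)n2C`, gives > 100000 nM, again a limit.
Compound 3, `COc1ccc(-c2cnc(NC(=O)c3cccc(C#N)c3)n2C)cc1`, gives > 100000 nM, also a limit.

Among the compounds with values here, compound 3 therefore stands where every value so far stands: at the upper edge of what the assay can report, with no number of its own. Within the data shown here, the evidence is uniform, (the limit of > 100000 nM in this assay, at which 3 of the 3 values shown sit), and no step between any two of the measured compounds can be sized, since none of them yields a figure.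

Compound 4, `COc1ccc(-c2cnc(NC(=O)c3ccccc3OC)n2C)cc1`, has not yet been measured in this assay. It differs from compound 3 in one place, (2-methoxyphenyl in place of 3-cyanophenyl on a carbonyl carbon). The amide-linked aryl group changes while the core of compound 3 is kept.

Since the measured compounds all sit at the limit, the only expectation that rests on them is that compound 4 stays there as well, with no step beyond the scatter in either direction. The step from compound 3 to compound 4 is estimated at a number no higher from compound 3 to compound 4 (the limit leaves the size open), which means compound 4 is expected to show 100000 nM in this assay, within a range of 50000 nM to 300000 nM, most likely reported again only as a limit.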

Compound 4, half-maximal cytotoxic concentration: > 100000 nM
Compound 4: only a limit was reported (the forecaster's own chance of this, stated with the estimate: 85%); the middle value lies on the limit itself.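

Within the data shown here, compound 3 and compound 4 both stand at a limit in this assay, not at a number, so no step between them can be read. The compounds shown leave open at what concentration any of them would become toxic to these cells, and whether the amide-linked aryl group has any bearing on that: the limit of > 100000 nM in this assay, at which 4 of the 4 values shown sit.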